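From allyl to 4-(trifluoromethyl)benzyl on the sulfur chain

The source may report more compounds than this note shows. Statements on the series, on what has been measured and on what is new or still open speak of the compounds shown alone.

In an ADME assay on GES1 cells (Homo sapiens) for inhibition, read by MTT assay, with a stated time of 72 h (on this read-out higher numbers stand for weaker inhibition and lower numbers for stronger inhibition), three compounds stand as follows:

Compound 1 `Cc1cc(Nc2cc(-c3ccccc3)[nH]n2)n2nc(SCCCc3ccccc3)nc2n1` gives 40200 nM
Compound 2 `C#CCSc1nc2nc(C)cc(Nc3cc(-c4ccccc4)[nH]n3)n2n1` gives 45700 nM
Compound 3 `C=CCSc1nc2nc(C)cc(Nc3cc(-c4ccccc4)[nH]n3)n2n1` gives > 50000 nM as a limit of the assay

Compound 3 stands at the limit of > 50000 nM in this assay, at which 1 of the 3 values shown sits, and so has a limit, not a number. Compound 4 `Cc1cc(Nc2cc(-c3ccccc3)[nH]n2)n2nc(SCc3ccc(C(F)(F)F)cc3)nc2n1` has not yet been measured. It differs from compound 3 as follows: 4-(trifluoromethyl)phenyl in place of vinyl on a saturated chain carbon bound to a sulfur.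

Among the measured compounds shown here, three measured steps bear on this change. The closest is an at least 1.2-fold higher number from compound 1 to compound 3 (0.09 log units; that floor lies within the scatter) and it starts from compound 1, whose phenethyl group, like the incoming group, holds an aromatic ring. The other two are a 1.1-fold higher number from compound 1 to compound 2 (0.06 log units; within the scatter) and an at least 1.0-fold higher number from compound 2 to compound 3 (0.03 log units; that floor lies within the scatter) and, like the first, they do not go beyond the scatter. Among compounds 1, 2 and 3, no exchange at this place has yet shifted this assay measurably. The estimated step is an at least 1.2-fold lower number from compound 3 to compound 4 (0.09 log units; that floor lies within the scatter) and it is expected to stay within the scatter. For compound 4 the expected value is 40000 nM with an estimated range of 20000 nM to 50000 nM and a real chance that the assay reports only a limit.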

Compound 4, half-maximal inhibitory concentration: 42700 nM
For compound 4 the middle estimate is 1.1-fold (0.03 log units) below the measured one; measured number inside the range.
By their numbers in this assay, from the lowest: compounds 1, 4 and 2 (each within the scatter of the next). At a limit, above all of these: compound 3.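

The 4-(trifluoromethyl)benzyl group extends what was seen with compounds 1, 2 and 3: an aromatic ring carrying fluorine, set on the saturated chain carbon bound to the sulfur, also leaves this assay without a measurable shift. Compared with the ethynyl and phenethyl compounds, the change reads as a 1.1-fold lower number from compound 2 to compound 4 (0.03 log units; within the scatter) and as a 1.1-fold higher number from compound 1 to compound 4 (0.03 log units; within the scatter), so a shorter link to the aromatic ring than in compound 1, with trifluoromethyl added, does not separate compound 4 from either. The comparison with the allyl compound reads as an at least 1.1-fold lower number from compound 3 to compound 4 (0.06 log units; that floor lies within the scatter), which is only a floor within the scatter, and compound 3 itself has a limit, not a number: the limit of > 50000 nM in this assay, at which 1 of the 4 values shown sits.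

On these data alone, whether any group at this place can move the read-out beyond the scatter remains open, for instance an amine or a carboxylic acid at the end of the sulfur chain. Also open, as far as these compounds go, is whether an unsubstituted benzyl group would read like compound 4, and how much of the read-out belongs to the shared core and not to the sulfur chain.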